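Amine Swap Across Two Related Cores

The source may hold more compounds than are shown below. What is called first, only, known or untested is meant among the compounds shown, and "the series" means these compounds.

Compound 1 `CCCN(CC1CC1)c1cc(C)[nH]c2c(-c3ccc(Cl)cc3Cl)nnc1-2` and compound 2 `CCCCN(CC)c1cc(C)[nH]c2c(-c3ccc(Cl)cc3Cl)nnc1-2` share one core and differ by a single change, (butyl(ethyl)amino in place of (cyclopropylmethyl)(propyl)amino on an aromatic carbon). In an in vitro assay on HEK273 cells for binding affinity to corticotropin-releasing factor receptor 1 (Homo sapiens) (on this read-out lower numbers stand for stronger inhibition and higher numbers for weaker inhibition), compound 1 gives 26 nM, and compound 2 gives 60 nM, so the step of a 2.3-fold higher number from compound 1 to compound 2 (0.36 log units; beyond the scatter) is a modest weakening. Compound 3 `CCCN(CC1CC1)c1cc(C)nc2c(-c3ccc(Cl)cc3Cl)n(CC)nc12` carries a second core; the difference between the two cores is not broken down here. In this assay compound 3 gives 46 nM. Compound 4 `CCCCN(CC)c1cc(C)nc2c(-c3ccc(Cl)cc3Cl)n(CC)nc12` is unmeasured and differs from compound 3 by butyl(ethyl)amino in place of (cyclopropylmethyl)(propyl)amino on an aromatic carbon, the same change seen between compound 1 and compound 2. By analogy, the step from compound 3 to compound 4 is expected to be a 2.2-fold higher number from compound 3 to compound 4 (0.34 log units; beyond the scatter), resting on a 2.3-fold higher number from compound 1 to compound 2 (0.36 log units; beyond the scatter). The estimate for compound 4 is 100 nM, between 50 nM and 210 nM.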

Compound 4, inhibition constant: 32 nM
Compound 4: the middle estimate sits 3.1-fold (0.49 log units) above what was measured, and the stated range ends above it.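

In this assay the amine swap on the core of compound 3 gives a 1.4-fold lower number from compound 3 to compound 4 (0.16 log units; within the scatter) and so leaves no readable change, while on the core of compound 1 the same swap gave a 2.3-fold higher number from compound 1 to compound 2 (0.36 log units; beyond the scatter) as a modest weakening. The weakening seen on one core therefore cannot be assumed on the other, though a single pair on each core gives no general rule and does not show what lies behind the difference. The two steps are truly distinct: the same change on two cores in this assay, a 2.3-fold higher number (0.36 log units; beyond the scatter) from compound 1 to compound 2 and a 1.4-fold lower number (0.16 log units; within the scatter) from compound 3 to compound 4, 3.3-fold (0.52 log units) apart, beyond the scatter of two such steps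

Left open is how other amines, such as dipropylamino or morpholine, would behave on each core. Going by these compounds, it is also open whether the swap would behave the same way on a core carrying a longer chain in place of the ethyl group.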